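This account rests on a few compounds, and the source may have more. Where it says the series, first, only, none or still open, it means among the compounds named here.

Measured so far: compound 1 `CCCCOC(=O)Nc1ccc([Se]C#N)cc1`, 6.6%; compound 2 `CC(C)COC(=O)Nc1ccc([Se]C#N)cc1`, 27.1%.

Going by the values given here, in a physicochemical assay, with a stated time of 180 min, tested at 0.5 mg/mL (a lower number here means less inhibition, a higher number more inhibition at the concentration tested (going by the name of the read-out)), compound 2 stands highest of the two numbers, with compound 1 the nearest, and the single measured step, a number 20.5 percentage points higher from compound 1 to compound 2 (beyond the scatter), separates them. Compound 3 `CCCCCCOC(=O)Nc1ccc([Se]C#N)cc1` is not yet measured; it differs from compound 2 by pentyl in place of isopropyl on a saturated chain carbon bound to an oxygen next to a carbonyl group. That one measured step bears on this change only in part: it ran from a straight chain to a branched one, whereas compound 3 returns to a straight chain, longer than in compound 1. A step back down toward the value of compound 1 is therefore expected. The expected step is a number 17.1 percentage points lower from compound 2 to compound 3 (beyond the scatter). Compound 3 is estimated at 10%, range 0% to 30%.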

Compound 3, a percentage reported as inhibition, at one concentration (the size of the read-out at that concentration, not a potency): > 25%
Compound 3 was reported as a limit; the forecaster's own chance of this, stated with the estimate: 0%; at least 15 percentage points between middle value and limit.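

In this assay, compound 3 gives > 25%, a limit of the assay and not a number. The longer straight chain, with ethyl in place of hydrogen on a saturated chain carbon, still gives a number at least 18.4 percentage points higher from compound 1 to compound 3 (beyond the scatter), so among these compounds a branched chain is not required for a higher read-out. The step between compound 2 and compound 3 cannot be read. As far as these compounds go, whether hexyl or isobutyl gives the higher read-out stays open. Also open, from the compounds shown here alone, is how a longer chain, or a chain ending in an amine or a carboxylic acid, would read here.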